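The compounds below may be only part of what the source reports. "The series", "measured", "known", "first", "only" and "open" are said of these compounds alone.

Compound 1 `CC(C)CCn1nc(-c2cccs2)c(O)c(C2=NS(=O)(=O)c3cc(O)ccc3N2)c1=O` carries a free hydroxy on the aromatic ring of the shared core. In an ADME assay on Huh-7 cells (Homo sapiens) for cytotoxicity, with a stated time of 72 h (on this read-out higher numbers stand for lower toxicity in this test and lower numbers for higher toxicity in this test), compound 1 gives > 25000 nM, which is a limit of the assay and not a number. Compound 2 `CC(C)CCn1nc(-c2cccs2)c(O)c(C2=NS(=O)(=O)c3cc(OC(C)(C)C(N)=O)ccc3N2)c1=O` gives > 33000 nM in this assay, also a limit. Compound 3 `CC(C)CCn1nc(-c2cccs2)c(O)c(C2=NS(=O)(=O)c3cc(OCC(=O)NO)ccc3N2)c1=O` gives > 33000 nM in this assay, again a limit. With all values at limits, the limit of > 25000 nM in this assay, at which 1 of the 3 values shown sits, and (the limit of > 33000 nM in this assay, at which 2 of the 3 values shown sit), the steps a step that the two limits leave unreadable from compound 1 to compound 2 and a step that the two limits leave unreadable from compound 1 to compound 3 cannot be sized. Compound 4 `CC(C)CCn1nc(-c2cccs2)c(O)c(C2=NS(=O)(=O)c3cc(OCC#N)ccc3N2)c1=O` differs from compound 1 by cyanomethyl in place of hydrogen on an oxygen on an aromatic ring. The two measured changes at the same oxygen bear on this step but give no readable size. Compound 4 is expected to sit at the limit as well, with an expected step that the limit leaves unreadable from compound 1 to compound 4. The estimate for compound 4 is 33000 nM, ranging from 20000 nM to 60000 nM.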

Compound 4, half-maximal cytotoxic concentration: > 33000 nM
Compound 4: only a limit was reported; the forecaster's own chance of this, stated with the estimate: 85%; the middle value sits exactly at the limit.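

Compound 4 also stands at a limit, and its steps from compound 1, compound 2 and compound 3 cannot be read. The compounds shown leave open how far any of these groups on the oxygen shifts the read-out in this assay.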